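This account rests on a few compounds, and the source may have more. Where it says the series, first, only, none or still open, it means among the compounds named here.

Measured so far in an in vitro ADME assay on microsomes from liver (Mus musculus) for metabolic stability, read by LC-MS, tested at 1 uM; a higher number here means that the compound lasts longer, a lower number that the compound disappears faster:
compound 1 `CC(C)n1ccnc1/N=C(\N)Nc1ccc(Cl)c(Cl)c1` gives 0.462 h
compound 2 `CC(C)N/C(=N\c1nccn1Cc1ccccc1)Nc1ccc(Cl)c(Cl)c1` gives 0.3 h
compound 3 `CC(C)C(=O)N/C(=N/c1nccn1C(C)C)Nc1ccc(Cl)c(Cl)c1` gives > 1 h

Compound 1 and compound 2 both give plain numbers in this assay. Compound 3 is different: its result is only a limit of the assay and not a number, so compound 3 stands at the limit of > 1 h in this assay, at which 1 of the 3 values shown sits. Where its true half-life lies beyond that is not known.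

Compound 4 `CC(C)n1ccnc1/N=C(/NC(=O)OC(C)(C)C)Nc1ccc(Cl)c(Cl)c1` has not yet been measured. It differs from compound 3 in one place: tert-butoxy in place of isopropyl on a carbonyl carbon. Within the data shown here, no pair of measured compounds differs in a single place, so there is no measured step of comparable kind to lean on. The change from compound 3 to compound 4 is expected to stay within the scatter, a step that the limit leaves unreadable from compound 3 to compound 4. Compound 4 is therefore estimated at 1.5 h, with a range from 0.5 h to 4 h.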

Compound 4, half-life: > 1 h
Compound 4: no number, only a limit (the forecaster's own chance of this, stated with the estimate: 60%); the middle value is on the limit's open side.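

Among these compounds, compound 3 and compound 4 both stand at a limit of the assay rather than at a number, so no step between them can be read: the limit of > 1 h in this assay, at which 2 of the 4 values shown sit.

From the compounds shown here alone, how long either compound truly lasts, and what tert-butoxy in place of isopropyl on a carbonyl carbon does to the half-life, stays open.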